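Benzyl ether variation on the isoflavone-type trimethoxyphenyl series

The source may report more compounds than this note shows. Statements on the series, on what has been measured and on what is new or still open speak of the compounds shown alone.

Compound 1 `C=CCOc1ccc2c(=O)c(-c3cc(OC)c(OC)cc3OC)coc2c1` and compound 2 `COc1cc(OC)c(-c2coc3cc(OCc4ccc([N+](=O)[O-])cc4)ccc3c2=O)cc1OC` share one core and differ only at the saturated chain carbon bound to an oxygen on the aromatic ring. In a functional assay on HepG2 cells (Homo sapiens) for antiproliferative activity, read by MTT assay, with a stated time of 24 h (a higher number here means a weaker inhibitor, a lower number a stronger inhibitor), compound 1 gives 3450 nM, and in this assay compound 2 gives 2500 nM. Going by the values given here, the one measured step at this position, a 1.4-fold lower number from compound 1 to compound 2 (0.14 log units; within the scatter), leaves compound 2 with the lower of the two numbers, though the two values cannot be told apart. Compound 3 `COc1cc(OC)c(-c2coc3cc(OCc4cccc(Br)c4)ccc3c2=O)cc1OC` keeps the same place of change: 3-bromophenyl in place of 4-nitrophenyl on a saturated chain carbon bound to an oxygen on an aromatic ring. Among the compounds with values here, the only step that bears on it is the one from vinyl to 4-nitrophenyl, which stayed within the scatter, so no step beyond the scatter is expected here either, in neither direction. Compound 3 is therefore expected to give about 2600 nM in this assay, within 1100 nM to 6000 nM, which would be an expected step of a 1.0-fold higher number from compound 2 to compound 3 (0.02 log units; within the scatter).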

Compound 3, half-maximal inhibitory concentration: 870 nM
The estimate for compound 3 lay 3.0-fold (0.48 log units) above the measured number; measured number outside the range, below it.
By their numbers in this assay, from the lowest: compound 3; then compounds 2 and 1 (each within the scatter of the next).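

In this assay this position, on a saturated chain carbon bound to an oxygen on an aromatic ring, now separates its substituents: a 2.9-fold lower number from compound 2 to compound 3 (0.46 log units; beyond the scatter) and a 4.0-fold lower number from compound 1 to compound 3 (0.60 log units; beyond the scatter), both beyond the scatter, whereas the earlier step from vinyl to 4-nitrophenyl stayed within it. Compound 3 therefore has the lowest number of the three, and the difference between 4-nitrobenzyl and 3-bromobenzyl shows that two benzyl ethers need not read alike. No measurement on hand accounts for the lower number.

The step from 4-nitrophenyl to 3-bromophenyl changes both the substituent and where it sits, so the two contributions cannot be told apart here. Also open, from the compounds shown here alone, is how an unsubstituted phenyl, an amine or a carboxylic acid on the ring, or a longer chain would read.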